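A few compounds are considered here, and "the series" means these few. Any claim that something is new, unique, unknown or untested is made for them only; others in the source may bear on it.

Among the compounds with values here, compound 2 `O=C(/C=C/c1cccc(NS(=O)(=O)c2cc(Cl)cc(Cl)c2)c1)c1nc2ccccc2[nH]1` gives 2840 nM in a functional assay on HCT-116 cells (Homo sapiens) for antiproliferative activity, read by MTT assay, with a stated time of 48 h (on this read-out higher numbers stand for weaker inhibition and lower numbers for stronger inhibition), the higher of the two numbers known; compound 1 `O=C(/C=C/c1cccc(NS(=O)(=O)c2ccccc2Cl)c1)c1nc2ccccc2[nH]1` gives 987 nM. Within the data shown here, that step, a 2.9-fold higher number from compound 1 to compound 2 (0.46 log units; beyond the scatter), is the only measured change at the sulfonyl sulfur. Compound 3 `Cc1ccc(S(=O)(=O)Nc2cccc(/C=C/C(=O)c3nc4ccccc4[nH]3)c2)cc1C` differs from compound 2 by 3,4-dimethylphenyl in place of 3,5-dichlorophenyl on a sulfonyl sulfur. Neither measured compound carries the entering group, so the measured step bears only loosely on this change and points to a modest shift at most, its direction uncertain. For compound 3 the expected step is a 1.6-fold lower number from compound 2 to compound 3 (0.20 log units; within the scatter). The estimate for compound 3 is 1800 nM, within 600 nM to 5500 nM.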

Compound 3, half-maximal inhibitory concentration: 2230 nM
Estimate against measurement, compound 3: 1.2-fold (0.09 log units) below; measured number inside the range.
By their numbers in this assay, from the lowest: compound 1; then compounds 3 and 2 (each within the scatter of the next).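

Placing 3,4-dimethylphenyl on the sulfonyl sulfur instead of 3,5-dichlorophenyl leaves the number within the scatter, with a 1.3-fold lower number from compound 2 to compound 3 (0.11 log units; within the scatter), so at this position this exchange of a chlorine-bearing ring for an all-carbon one has no readable effect. Compound 1 now stands apart from a second compound, with a 2.3-fold higher number from compound 1 to compound 3 (0.35 log units; beyond the scatter), making it the most potent of the three.

On these data alone, whether a phenyl carrying an amine or a carboxylic acid on the sulfonyl sulfur would read nearer compound 1 or compound 2 remains open. Nothing available explains these differences.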